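The source may hold more compounds than are shown below. What is called first, only, known or untested is meant among the compounds shown, and "the series" means these compounds.

Compound 1, `CSc1nc2c(C)nsc2[nH]1`, and compound 2, `CSc1nc2cnsc2[nH]1`, share one core; compound 3, `CSc1nc2c(C)nsc2n1[C@H]1C[C@H](O)[C@@H](CO)O1`, and the as yet unmeasured compound 4, `CSc1nc2cnsc2n1[C@H]1C[C@H](O)[C@@H](CO)O1`, share another. The difference between the two cores is not broken down here. In a functional assay on L1210 cells (Mus musculus) for antiproliferative activity (a higher number here means a weaker inhibitor, a lower number a stronger inhibitor), compound 1 gives 13000 nM, and compound 2 gives 7000 nM. The change between them, (hydrogen in place of methyl on an aromatic carbon), made a step of a 1.9-fold lower number from compound 1 to compound 2 (0.27 log units; within the scatter). For compound 3 this assay reports only a limit, > 100000 nM, at the limit of > 100000 nM in this assay, at which 1 of the 3 values shown sits. The same change, (hydrogen in place of methyl on an aromatic carbon), leads from compound 3 to compound 4. Because a 1.9-fold lower number from compound 1 to compound 2 (0.27 log units; within the scatter) lay within the scatter, the analogous step is expected to be about a number no higher from compound 3 to compound 4 (the limit leaves the size open). Compound 4 is thus estimated at 100000 nM, between 30000 nM and 300000 nM, and may well be reported only as a limit.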

Compound 4, half-maximal inhibitory concentration: > 100000 nM
Compound 4 ended at the assay's limit; the forecaster's own chance of this, stated with the estimate: 70%; the middle value lies on the limit itself.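

No step can be read between compound 3 and compound 4 in this assay, since each stands only as a limit: the limit of > 100000 nM in this assay, at which 2 of the 4 values shown sit.

The compounds shown leave open what hydrogen in place of methyl does on the core of compound 3.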